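The compounds below may be only part of what the source reports. "The series", "measured", "known", "first", "only" and "open" are said of these compounds alone.

Of the compounds shown here, three have so far been measured in an assay on isolated protein for inhibition of protein deacetylase HDAC6 (Homo sapiens), tested at 0.5 uM; a higher number here means more inhibition at the concentration tested (going by the name of the read-out), a lower number less inhibition. Compound 1 `COc1cc(OC)c2c(N3CCCC3)nc(-c3ccc(C(=O)NO)cc3)nc2c1` gives 55.3%. Compound 2 `COc1cc(OC)c2c(N3CCCCC3)nc(-c3ccc(C(=O)NO)cc3)nc2c1` gives 62.5% in this assay. Among the measured compounds shown here, the only change between the two is piperidin-1-yl in place of pyrrolidin-1-yl on an aromatic carbon, and this change made a step of a number 7.2 percentage points higher from compound 1 to compound 2 (within the scatter). Compound 3 `O=C(NO)c1ccc(-c2nc(N3CCCC3)c3ccc(Cl)cc3n2)cc1` is built on another core; how its core differs from that of compound 1 is not broken down here. In this assay compound 3 gives 54.6%.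

Compound 4 `O=C(NO)c1ccc(-c2nc(N3CCCCC3)c3ccc(Cl)cc3n2)cc1` has not yet been measured. For the measured compounds named here, it differs from compound 3 by piperidin-1-yl in place of pyrrolidin-1-yl on an aromatic carbon, which is the same change as the one from compound 1 to compound 2, since the surroundings of the place are described in exactly the same words. Because the earlier instance of this change produced a number 7.2 percentage points higher from compound 1 to compound 2 (within the scatter), a step of similar small size is expected here, staying within the scatter. The step from compound 3 to compound 4 in this assay is therefore expected to be a number 5.4 percentage points higher from compound 3 to compound 4 (within the scatter). Compound 4 is estimated at 60%, with a likely range from 48% to 72%.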

Compound 4, a percentage reported as inhibition, at one concentration (the size of the read-out at that concentration, not a potency): 59.6%
Compound 4: the middle estimate sits 0.4 percentage points above what was measured; measured number inside the range.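

In this assay, placing piperidin-1-yl where pyrrolidin-1-yl stood on the second core gave a number 5 percentage points higher from compound 3 to compound 4 (within the scatter). Set beside the same change on the first core, this step does not differ from the earlier one: the same change on two cores in this assay, a number 7.2 percentage points higher (within the scatter) from compound 1 to compound 2 and a number 5 percentage points higher (within the scatter) from compound 3 to compound 4, 2.2 percentage points apart, within the scatter of two such steps. The change therefore behaves alike on these two cores, but each step is small enough to be ordinary scatter, so the pairs do not show that piperidin-1-yl truly gives more inhibition than pyrrolidin-1-yl, nor that the agreement would hold on a third core.

Still open, going by these compounds, is what a different group would do at this place on either core, such as morpholin-4-yl, which brings a ring oxygen, or an open-chain amine such as diethylamino. On these data alone, these readings also come from a single concentration, so how the compounds compare in potency remains unknown, and a real difference between the two rings smaller than the scatter could not be seen here.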